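From 4-bromophenyl to 2-fluorophenyl on compound 1

The compounds below may be only part of what the source reports. "The series", "measured", "known", "first", "only" and "open" are said of these compounds alone.

In a functional assay on MM1 cells (Homo sapiens) for antiproliferative activity, read by MTT assay, with a stated time of 72 h (a higher number here means a weaker inhibitor, a lower number a stronger inhibitor), compound 1 `C[C@H](NC(=O)/C(C#N)=C/c1cccc(Br)n1)c1ccc(Br)cc1` gives 1500 nM and compound 2 `N#C/C(=C\c1cccc(Br)n1)C(=O)N[C@@H](CO)c1ccccc1` gives 2800 nM. These two numbers lie within the usual scatter of repeated measurements, so compound 1 cannot be ranked against compound 2.

Compound 3 `C[C@H](NC(=O)/C(C#N)=C/c1cccc(Br)n1)c1ccccc1F` differs from compound 1 in one place: 2-fluorophenyl stands in place of 4-bromophenyl on a saturated chain carbon bound to an amide-type nitrogen and a saturated chain carbon (2-fluorophenyl in place of 4-bromophenyl on a saturated chain carbon bound to an amide-type nitrogen and a saturated chain carbon). Among the compounds with values here, no measured pair of compounds differing in one place exists yet, so the data give no direct guide to this change. The only hint is how close the two known values are, with compound 2 at 2800 nM and compound 1 at 1500 nM. The expected step is therefore none beyond the scatter: a 1.3-fold higher number from compound 1 to compound 3 (0.12 log units; within the scatter). For compound 3 the estimated value is 2000 nM, with an expected range from 700 nM to 5500 nM.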

Compound 3, half-maximal inhibitory concentration: 1800 nM
Estimate against measurement, compound 3: 1.1-fold (0.05 log units) above; the range from low to high includes it.
By their numbers in this assay, from the lowest: compounds 1, 3 and 2 (each within the scatter of the next).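

In this assay, within the data shown here, placing 2-fluorophenyl where 4-bromophenyl stood on the saturated chain carbon gives a 1.2-fold higher number from compound 1 to compound 3 (0.08 log units; within the scatter), the first direct reading of a single change in this set, and it leaves the two compounds indistinguishable. At this position, the bromine-bearing ring and the fluorine-bearing ring, each with the same heavy-atom count, therefore cannot be told apart by this read-out, even though both the halogen and its place on the ring differ. Nothing available explains why the two compounds read alike.

From the compounds shown here alone, the compounds compared in one place carry only a halogen-bearing phenyl ring here, so it remains open whether a phenyl ring bearing an amine or a carboxylic acid would also read alike. One step also cannot show how a longer chain in place of the ring would behave.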